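This account rests on a few compounds, and the source may have more. Where it says the series, first, only, none or still open, it means among the compounds named here.

Measured in a functional assay on MCF7 cells (Homo sapiens) for inhibition; a lower number here means a stronger inhibitor, a higher number a weaker inhibitor:
- compound 1 `CC/C(=C(/c1ccc(/C=C/C(=O)O)cc1)c1cc2ccccc2[nH]1)c1ccccc1C`: 33 nM
- compound 2 `CC/C(=C(/c1ccc(/C=C/C(=O)O)cc1)c1cc2ccccc2[nH]1)c1ccccc1Cl`: 42 nM
- compound 3 `CC/C(=C(/c1ccc(/C=C/C(=O)O)cc1)c1cc2ccccc2[nH]1)c1cccc(Cl)c1Cl`: 898 nM

Compound 3 stands highest of the three numbers; its nearest neighbour is compound 2 and its furthest is compound 1, and both gaps lie beyond the scatter. Compound 4 `CC/C(=C(/c1ccc(/C=C/C(=O)O)cc1)c1cc2ccccc2[nH]1)c1ccc(Cl)cc1C(F)(F)F` carries 4-chloro-2-(trifluoromethyl)phenyl in place of 2,3-dichlorophenyl on a double-bonded chain carbon bound to a double-bonded chain carbon and a saturated chain carbon. For the measured compounds named here, two steps bear on this. The step of a 27-fold higher number from compound 1 to compound 3 (1.43 log units; beyond the scatter) and the step of a 21-fold higher number from compound 2 to compound 3 (1.33 log units; beyond the scatter) both show a large loss on reaching the 2,3-dichlorophenyl of compound 3, while the step of a 1.3-fold higher number from compound 1 to compound 2 (0.10 log units; within the scatter) shows nothing beyond the scatter between methyl and chloro there. Going by the values given here, compound 4 leaves the 2,3-dichlorophenyl behind, but no measured compound carries a 4-chloro or a trifluoromethyl on that ring, so the size of the step in this assay is uncertain; a move back toward the numbers of compounds 1 and 2 is expected, probably partial. Compound 4 is therefore estimated at 300 nM, in the range 60 nM to 1500 nM, meaning an expected step of a 3.0-fold lower number from compound 3 to compound 4 (0.48 log units; beyond the scatter).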

Compound 4, half-maximal inhibitory concentration: 4 nM
For compound 4 the middle estimate is 75-fold (1.88 log units) above the measured one; measured number outside the range, below it.
By their numbers in this assay, from the lowest: compound 4; then compounds 1 and 2 (each within the scatter of the next); then compound 3.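

In this assay, the ring on the double-bonded chain carbon does more than recover from the loss seen with 2,3-dichlorophenyl (a 220-fold lower number from compound 3 to compound 4 (2.35 log units; beyond the scatter)), as 4-chloro-2-(trifluoromethyl)phenyl also goes past both singly substituted rings (an 11-fold lower number from compound 2 to compound 4 (1.02 log units; beyond the scatter); an 8.3-fold lower number from compound 1 to compound 4 (0.92 log units; beyond the scatter)). Two substituents on this ring are thus not a loss in themselves, since compound 3 and compound 4 each carry two and stand at opposite ends of the series. Nothing measured on these compounds explains the gain, and no supporting evidence bears on this result.

For the compounds shown here, whether the gain follows the 4-chloro, the trifluoromethyl or only the pair remains open, as the two enter together in compound 4. Also open, as far as these compounds go, is whether a methoxy group or an amine on that ring would keep the gain.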